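Isopropyl for ethyl on the urea of compound 2

The source may hold more compounds than are shown below. What is called first, only, known or untested is meant among the compounds shown, and "the series" means these compounds.

Measured so far:
compound 1 `CC(C)NC(=O)N1CCN(C(=S)SCc2cn(Cc3ccccc3F)nn2)CC1` — 1860 nM
compound 2 `CCNC(=O)N1CCN(C(=S)SCc2cn(Cc3ccc(F)cc3)nn2)CC1` — 3660 nM

In a functional assay on MCF7 cells (Homo sapiens) for cytotoxicity, read by MTT assay, with a stated time of 72 h (a lower number here means a stronger inhibitor, a higher number a weaker inhibitor), compound 2 gives 3660 nM. Going by the values given here, its only neighbour is compound 1, which gives 1860 nM in this assay, a gap that falls within the usual scatter, so the two numbers cannot be told apart and no order between them is claimed.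

Compound 3 `CC(C)NC(=O)N1CCN(C(=S)SCc2cn(Cc3ccc(F)cc3)nn2)CC1` has not yet been measured. It differs from compound 2 in one place: methyl in place of hydrogen on a saturated chain carbon bound to an amide-type nitrogen and a saturated chain carbon. Among the compounds with values here, no step between measured compounds covers this change; compound 1 carries the isopropylcarbamoyl group but also a different fluorobenzyl, so it does not isolate the change.

The expected step of a 1.4-fold lower number from compound 2 to compound 3 (0.15 log units; within the scatter) in this assay is small and not beyond the scatter, given that compound 1 with 1860 nM and compound 2 with 3660 nM already sit close together. Compound 3 is expected at 2600 nM in this assay, within 1000 nM to 6500 nM.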

Compound 3, half-maximal inhibitory concentration: 1660 nM
The estimate for compound 3 lay 1.6-fold (0.19 log units) above the measured number, within the range that was stated.
By their numbers in this assay, from the lowest: compounds 3, 1 and 2 (each within the scatter of the next, the first and the last beyond it).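

In this assay, going by these compounds alone, a 2.2-fold lower number from compound 2 to compound 3 (0.34 log units; beyond the scatter) gives the first isolated reading of methyl in place of hydrogen on a saturated chain carbon bound to an amide-type nitrogen and a saturated chain carbon; this modest step, ethylcarbamoyl to isopropylcarbamoyl, lies beyond the scatter. With isopropylcarbamoyl held constant, 4-fluorophenyl in place of 2-fluorophenyl on a saturated chain carbon bound to an aromatic nitrogen gives a 1.1-fold lower number from compound 1 to compound 3 (0.05 log units; within the scatter), which is within the scatter, so the fluorine placement separates neither compound from the other in this assay. No measurement available for the series bears on the origin of the ethyl to isopropyl step.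

The compounds shown leave open how a tert-butyl group or a longer chain would read in place of isopropyl. Also open, on these data alone, is whether the ethyl to isopropyl step holds with 2-fluorophenyl in place of 4-fluorophenyl.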